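Extending the side chain on the shared core

The source may report more compounds than this note shows. Statements on the series, on what has been measured and on what is new or still open speak of the compounds shown alone.

Measured so far:
compound 1, `COc1cccc(Sc2c(NS(=O)(=O)c3ccc(C(C)(C)C)cc3)noc2CCC/C=N/O)c1`: 85 nM
compound 2, `COc1cccc(Sc2c(NS(=O)(=O)c3ccc(C(C)(C)C)cc3)noc2C)c1`: 300 nM

In an assay on COS-7 cells for displacement of a labelled ligand from Endothelin receptor type B (Sus scrofa) (a lower number here means a stronger inhibitor, a higher number a weaker inhibitor), compound 1 gives 85 nM, while compound 2 gives 300 nM. Compound 2 therefore stands at the higher of the two values, separated from compound 1 by a 3.5-fold higher number from compound 1 to compound 2 (0.55 log units; beyond the scatter).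

Compound 3, `COc1cccc(Sc2c(NS(=O)(=O)c3ccc(C(C)(C)C)cc3)noc2CCCC(N)=O)c1`, differs from compound 2 by 2-carbamoylethyl in place of hydrogen on a saturated chain carbon bound to an aromatic carbon. Among the measured compounds shown here, the only step that bears on this change is a 3.5-fold higher number from compound 1 to compound 2 (0.55 log units; beyond the scatter), in which a chain of like length left the very same place and the number rose modestly. For the measured compounds named here, that step suggests a chain at this position can bring the number back down, although the entering group here is not the one carried by compound 1, so the size of the return is uncertain. For compound 3 an expected step of a 2.5-fold lower number from compound 2 to compound 3 (0.40 log units; beyond the scatter) seems reasonable. Compound 3 is thus estimated at 120 nM, within a range of 40 nM to 350 nM.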

Compound 3, half-maximal inhibitory concentration: 240 nM
Estimate against measurement, compound 3: 2.0-fold (0.30 log units) below, and the stated range covers the measured number.
By their numbers in this assay, from the lowest: compound 1; then compounds 3 and 2 (each within the scatter of the next).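

In this assay, adding 2-carbamoylethyl on a saturated chain carbon bound to an aromatic carbon gives a 1.3-fold lower number from compound 2 to compound 3 (0.10 log units; within the scatter), so a chain at this place does not by itself set compound 3 apart from compound 2. The end of the chain does matter here: exchanging the end group, three bonds along the chain from an aromatic carbon, gives a 2.8-fold higher number from compound 1 to compound 3 (0.45 log units; beyond the scatter), which ties the lower number of compound 1 to its own chain end and not to chain length alone. Nothing available gives a reason for this difference between the two chain ends.

The compounds shown leave open whether a carboxylic acid or an amine at the chain end would stand with compound 1 or with compound 3. They also leave open what a longer chain would do at this place.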